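Second Nitro Group on a Weak Liver-Cell Inhibitor

This account rests on a few compounds, and the source may have more. Where it says the series, first, only, none or still open, it means among the compounds named here.

Compound 1 `NC1=NC(c2cn(-c3ccc([N+](=O)[O-])cc3)nc2-c2ccc(Cl)cc2Cl)N=C(N2CCOCC2)N1` — > 100000 nM
Compound 2 `CN(C)C1=NC(c2cn(-c3ccc([N+](=O)[O-])cc3)nc2-c2ccc(Cl)cc2Cl)N=C(N)N1` — > 100000 nM

In an ADME assay on L02 cells (Homo sapiens) for inhibition, read by MTT assay, with a stated time of 24 h (a higher number here means a weaker inhibitor, a lower number a stronger inhibitor), compound 1 gives > 100000 nM, which is a limit of the assay rather than a number. Compound 2 gives > 100000 nM in this assay, again a limit. The step that the two limits leave unreadable from compound 1 to compound 2 therefore cannot be read, because both values sit at the limit of > 100000 nM in this assay, at which 2 of the 2 values shown sit. Where compound 2 stands is thus known only as a limit: it is no stronger an inhibitor than that limit allows, and nothing says how much weaker it may be.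

Compound 3 `CN(C)C1=NC(c2cn(-c3ccc([N+](=O)[O-])cc3[N+](=O)[O-])nc2-c2ccc(Cl)cc2Cl)N=C(N)N1` differs from compound 2 by nitro in place of hydrogen on an aromatic carbon. Among the measured compounds shown here, no measured step shows a nitro group entering in this way, so no size can be borrowed from a measured pair; the only guidance is that both measured compounds sit at the limit. Compound 3 is therefore expected to stay at that limit, with the estimated step of a number no higher from compound 2 to compound 3 (the limit leaves the size open) meaning no change beyond the scatter. For compound 3 the estimate in this assay is 100000 nM, within a range from 40000 nM to 300000 nM.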

Compound 3, half-maximal inhibitory concentration: > 100000 nM
Compound 3 ended at the assay's limit; the forecaster's own chance of this, stated with the estimate: 85%; the middle value sits exactly at the limit.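

The step from compound 2 to compound 3, nitro in place of hydrogen on an aromatic carbon, cannot be read, because compound 1, compound 2 and compound 3 all rest on the same limit rather than on numbers: the limit of > 100000 nM in this assay, at which 3 of the 3 values shown sit.

Going by these compounds, what stays open is how far each compound lies beyond that limit in this assay, and whether the three differ at all.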